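The source may report more compounds than this note shows. Statements on the series, on what has been measured and on what is new or still open speak of the compounds shown alone.

Working notes on a shared core. Compound 1 `CCNC(=O)Cn1nc(N)c2c(C(F)(F)F)cc(-c3ccccc3)nc21` is the reference point of the set. In a functional assay on MCF7 cells (Homo sapiens) for cytotoxicity, read by MTT assay, with a stated time of 24 h (on this read-out higher numbers stand for weaker inhibition and lower numbers for stronger inhibition), compound 1 gives 21300 nM, the highest of the three numbers in hand. Compound 2 `Nc1nn(CC(=O)NCc2ccco2)c2nc(-c3ccccc3)cc(C(F)(F)F)c12` gives 5000 nM in this assay, and compound 3 `Nc1nn(CC(=O)NC2CCCCC2)c2nc(-c3ccccc3)cc(C(F)(F)F)c12` gives 5200 nM in this assay. Two measured steps start from compound 1: a 4.3-fold lower number from compound 1 to compound 2 (0.63 log units; beyond the scatter), and a 4.1-fold lower number from compound 1 to compound 3 (0.61 log units; beyond the scatter). Between the two larger amide substituents the step is a 1.0-fold higher number from compound 2 to compound 3 (0.02 log units; within the scatter).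

Compound 4 `CC(NC(=O)Cn1nc(N)c2c(C(F)(F)F)cc(-c3ccccc3)nc21)C(=O)O` has not been measured. It differs from compound 1 by carboxy in place of hydrogen on a saturated chain carbon bound to an amide-type nitrogen and a saturated chain carbon. Both measured steps away from compound 1 replaced the small group on the amide-type nitrogen with a larger one and each gave a modest lowering beyond the scatter. Within the data shown here, the change to compound 4 is of a different kind: the ethyl stays and a carboxy is added on its inner chain carbon, so no measured step covers it directly. Among the measured compounds shown here, the steps from compound 1 to compounds 2 and 3 suggest that growth at this position can lower the number, but the carboxy itself has no precedent here, so the expected step in this assay is small and downward, possibly within the scatter. The expected step is a 1.4-fold lower number from compound 1 to compound 4 (0.15 log units; within the scatter). For compound 4 the estimated value in this assay is 15000 nM, with a range from 6000 nM to 40000 nM.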

Compound 4, half-maximal inhibitory concentration: 19900 nM
Compound 4: middle estimate off by 1.3-fold (0.12 log units), on the low side; the range from low to high includes it.
By their numbers in this assay, from the lowest: compounds 2 and 3 (each within the scatter of the next); then compounds 4 and 1 (each within the scatter of the next).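

In this assay, carboxy in place of hydrogen on a saturated chain carbon bound to an amide-type nitrogen and a saturated chain carbon gives a result that cannot be told apart from compound 1 (a 1.1-fold lower number from compound 1 to compound 4 (0.03 log units; within the scatter)), so this added group, unlike the larger amide substituents of compound 2 and compound 3, comes with no step beyond the scatter. Among the four compounds, a larger substituent on the amide-type nitrogen therefore does not always go with a lower number: compound 4 goes against that reading, with 1-carboxyethyl in place of cyclohexyl (a 3.8-fold higher number from compound 3 to compound 4 (0.58 log units; beyond the scatter)) and in place of (furan-2-yl)methyl (a 4.0-fold higher number from compound 2 to compound 4 (0.60 log units; beyond the scatter)). No supporting data bear on why compound 4 stands with compound 1 rather than with compound 2 and compound 3.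

A methyl ester or an amine in place of the carboxy on the same chain carbon would show whether the result for compound 4 is specific to the carboxylic acid. A longer chain ending in a carboxylic acid, or a carboxy on the cyclohexyl ring of compound 3, would show whether it holds elsewhere on the amide substituent.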